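A few compounds are considered here, and "the series" means these few. Any claim that something is new, unique, unknown or untested is made for them only; others in the source may bear on it.

The measured compounds: compound 1 `CCc1ccccc1N(Cc1nnc(Cc2ccc(OC)cc2)o1)S(=O)(=O)c1ccc(C)cc1` gives 631 nM in a functional assay on CHO cells for antagonist activity at prostaglandin E2 receptor EP1 subtype (Homo sapiens), read by FLIPR and calcium flux; on this read-out higher numbers stand for weaker inhibition and lower numbers for stronger inhibition; compound 2 `CCOc1ccc(Cc2nnc(CN(c3ccccc3CC)S(=O)(=O)c3ccc(C)cc3)o2)cc1` gives 39.8 nM; compound 3 `CCOc1ccc(Cc2nnc(CN(c3cccc(Cl)c3Cl)S(=O)(=O)c3ccc(C)cc3)o2)cc1` gives 31.6 nM.

Compound 2 stands second highest of the three numbers. Its nearest neighbour is compound 3, with a step of a 1.3-fold lower number from compound 2 to compound 3 (0.10 log units; within the scatter) that lies within the scatter. Its furthest is compound 1, separated by the large step of a 16-fold lower number from compound 1 to compound 2 (1.20 log units; beyond the scatter).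

Compound 4 `CCc1ccccc1N(Cc1nnc(COc2ccc(OC)cc2)o1)S(=O)(=O)c1ccc(C)cc1` differs from compound 2 by 4-methoxyphenoxy in place of 4-ethoxyphenyl on a saturated chain carbon bound to an aromatic carbon. Of the measured steps, the one that bears on this change is a 16-fold lower number from compound 1 to compound 2 (1.20 log units; beyond the scatter), which touched the same alkoxy group on the same aromatic ring and was large. The step of a 1.3-fold lower number from compound 2 to compound 3 (0.10 log units; within the scatter) altered the group on the sulfonamide nitrogen and lies within the scatter, so it says little about this part of the structure. Compound 4 returns to a methoxy group on that ring, as in compound 1, while the oxygen inserted into the chain has no measured counterpart among these three compounds. A higher number than that of compound 2 is therefore expected, with the step of a 7.5-fold higher number from compound 2 to compound 4 (0.88 log units; beyond the scatter) estimated to be beyond the scatter but uncertain in size. Compound 4 is estimated at 300 nM, with a range from 60 nM to 1500 nM.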

Compound 4, inhibition constant: 126 nM
Estimate against measurement, compound 4: 2.4-fold (0.38 log units) above; low and high end bracket the measured number.
By their numbers in this assay, from the lowest: compounds 3 and 2 (each within the scatter of the next); then compound 4; then compound 1.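

Going by these compounds alone, with the methoxy group held in place in this assay, 4-methoxyphenoxy gives stronger inhibition than 4-methoxyphenyl (a 5.0-fold lower number from compound 1 to compound 4 (0.70 log units; beyond the scatter)), so this position can take a change in the link to the ring as well as in the alkoxy group, a change the earlier compounds did not touch. The oxygen-containing group still falls short of 4-ethoxyphenyl (a 3.2-fold higher number from compound 2 to compound 4 (0.50 log units; beyond the scatter)), so among the groups shown at this position, the one carried by compound 2 remains the better of the two, even though both groups have the same count of heavy atoms and the entering group adds a hydrogen-bond acceptor. Nothing among the data given accounts for either step.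

On these data alone, it remains open whether the gains seen with the ethoxy group and with the oxygen in the chain would add together in a 4-ethoxyphenoxy group, or whether a longer chain such as propoxy would extend the trend from methoxy to ethoxy. The compounds shown also leave open whether 4-methoxyphenoxy would behave the same way alongside the 2,3-dichlorophenyl group of compound 3.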